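Notes on the benzylpiperazine analogue, compound 4

The compounds below may be only part of what the source reports. "The series", "measured", "known", "first", "only" and "open" are said of these compounds alone.

Measured in a functional assay on HT-29 cells (Homo sapiens) for cytotoxicity, read by MTT assay, with a stated time of 24 h, tested at 80 ug/mL; on this read-out higher numbers stand for a stronger effect at the one concentration tested and lower numbers for a weaker effect:
compound 1 `Cn1cnnc1SCC(=O)Nc1ccc(-c2nc(-c3ccccc3)c(-c3ccccc3)n2C)cc1`: 88%
compound 2 `Cn1nnnc1SCC(=O)Nc1ccc(-c2nc(-c3ccccc3)c(-c3ccccc3)n2C)cc1`: 89%
compound 3 `CCN1CCN(CC(=O)Nc2ccc(-c3nc(-c4ccccc4)c(-c4ccccc4)n3C)cc2)CC1`: 51.2%

Compound 3 stands lowest of the three: the steps of a number 36.8 percentage points lower from compound 1 to compound 3 (beyond the scatter) and a number 37.8 percentage points lower from compound 2 to compound 3 (beyond the scatter) are both beyond the scatter, whereas compound 1 and compound 2 differ only by a number 1 percentage points higher from compound 1 to compound 2 (within the scatter). Compound 4 `Cn1c(-c2ccc(NC(=O)CN3CCN(Cc4ccccc4)CC3)cc2)nc(-c2ccccc2)c1-c1ccccc1` keeps the piperazine amide of compound 3 and changes it by phenyl in place of methyl on a saturated chain carbon bound to an amine nitrogen in a ring. Within the data shown here, no measured step touches the group on the piperazine nitrogen; the two large steps replace a sulfanyl-linked heterocycle with 4-ethylpiperazin-1-yl and do not bear on this change. No step beyond the scatter is therefore expected in this assay, in either direction. Compound 4 is estimated at 52%, range 35% to 70%. This expectation means a number 0.8 percentage points higher from compound 3 to compound 4 (within the scatter).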

Compound 4, a percentage reported as activity, at one concentration (the size of the read-out at that concentration, not a potency): 54.5%
Compound 4: the middle estimate sits 2.5 percentage points below what was measured; low and high end bracket the measured number.
By their numbers in this assay, from the lowest: compounds 3 and 4 (each within the scatter of the next); then compounds 1 and 2 (each within the scatter of the next).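

Phenyl in place of methyl on a saturated chain carbon bound to an amine nitrogen in a ring gives, in this assay, a number 3.3 percentage points higher from compound 3 to compound 4 (within the scatter) and so adds a first reading at this place. The earlier compounds shown here carried only ethyl here, so they could not show that ethyl to benzyl leaves the read-out within the scatter. No available evidence explains this result.

Still open, as far as these compounds go, is whether a carboxylic acid or a longer chain ending in an amine at this place would give a step beyond the scatter. Also open, from the compounds shown here alone, is whether a substituted benzyl would stay within it.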